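From Compound 3 to Compound 4: One Group Exchanged

The compounds below may be only part of what the source reports. "The series", "measured", "known", "first", "only" and "open" are said of these compounds alone.

In a toxicity assay on L02 cells (Homo sapiens) for cytotoxicity, read by MTT assay, with a stated time of 72 h (a lower number here means a stronger inhibitor, a higher number a weaker inhibitor), compound 1 (`CC1(C)OCC(Cn2cc(Cn3c4c(c5ccccc53)C(=O)c3c[n+]([O-])c5ccccc5c3C4=O)nn2)O1`) gives 120 nM, compound 2 (`CC1(C)OC[C@H](Cn2cc(Cn3c4c(c5ccccc53)C(=O)c3c[n+]([O-])c5ccccc5c3C4=O)nn2)O1`) gives 470 nM and compound 3 (`CC1(C)OC[C@@H](Cn2cc(Cn3c4c(c5ccccc53)C(=O)c3c[n+]([O-])c5ccccc5c3C4=O)nn2)O1`) gives 2900 nM. Compound 3 therefore has the highest number of the three, making it the weakest inhibitor so far. Compound 4 (`O=C1c2c[n+]([O-])c3ccccc3c2C(=O)c2c1c1ccccc1n2Cc1cn([C@H]2C[C@H](O)[C@@H](CO)O2)nn1`) keeps the shared core but carries 4-hydroxy-5-(hydroxymethyl)oxolan-2-yl in place of (2,2-dimethyl-1,3-dioxolan-4-yl)methyl on an aromatic nitrogen.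

Within the data shown here, no measured step exchanges a group, so the evidence is indirect. The closest guide is a 6.2-fold higher number from compound 2 to compound 3 (0.79 log units; beyond the scatter), which traces to the fact that compounds 2 and 3 differ only in the configuration as drawn. The other two steps are a 3.9-fold higher number from compound 1 to compound 2 (0.59 log units; beyond the scatter), tied to the fact that one of compounds 1 and 2 is drawn with a defined configuration and the other without, at the place where they differ, and a 24-fold higher number from compound 1 to compound 3 (1.38 log units; beyond the scatter), tied to the fact that one of compounds 1 and 3 is drawn with a defined configuration and the other without, at the place where they differ. Together they show that this side of the molecule can shift the number modestly or largely. Because compound 3 stands at 2900 nM at the top of the range, a modest move to a lower number seems likelier than a further rise, though the uncertainty is wide. The expected change is a 2.9-fold lower number from compound 3 to compound 4 (0.46 log units; beyond the scatter). For compound 4, the estimated value in this assay is 1000 nM, with an expected range from 180 nM to 5500 nM.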

Compound 4, half-maximal inhibitory concentration: 280 nM
The estimate for compound 4 lay 3.6-fold (0.55 log units) above the measured number; the range from low to high includes it.
By their numbers in this assay, from the lowest: compound 1; then compounds 4 and 2 (each within the scatter of the next); then compound 3.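

In this assay, exchanging (2,2-dimethyl-1,3-dioxolan-4-yl)methyl for 4-hydroxy-5-(hydroxymethyl)oxolan-2-yl on the aromatic nitrogen reads differently against each earlier compound: a 10-fold lower number from compound 3 to compound 4 (1.02 log units; beyond the scatter) is large, a 1.7-fold lower number from compound 2 to compound 4 (0.22 log units; within the scatter) is not a real difference, and a 2.3-fold higher number from compound 1 to compound 4 (0.37 log units; beyond the scatter) is modest. The entering group carries 2 hydrogen-bond donors and the leaving group none, yet the number for compound 4 falls inside the range already spanned by compounds 1 to 3. The choice of comparison matters because the two defined forms of the leaving group are themselves far apart: the fact that compounds 2 and 3 differ only in the configuration as drawn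

Compound 4 changes the ring, the hydroxy groups and the stereocentres together, so the compounds shown cannot tell which of these accounts for the steps. Going by these compounds, how an amine or a simple 2,3-dihydroxypropyl chain would behave on this nitrogen also remains open.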